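Removing the isopropylcarbonyl from compound 1

The source may hold more compounds than are shown below. What is called first, only, known or untested is meant among the compounds shown, and "the series" means these compounds.

Compound 1, `COc1ccccc1N1CCN(CCNc2c(C(=O)C(C)C)c(-c3ccccc3)nn(C)c2=O)CC1`: 0.64 nM
Compound 2, `COc1ccccc1N1CCN(CCCNc2c(C(C)=O)c(-c3ccccc3)nn(C)c2=O)CC1`: 20.3 nM

In an assay on isolated protein for binding affinity to Alpha-1B adrenergic receptor (Homo sapiens), read by radioligand binding (on this read-out higher numbers stand for weaker inhibition and lower numbers for stronger inhibition), compound 1 gives the lower of the two numbers recorded so far, with 0.64 nM; compound 2 gives a higher number, 20.3 nM, a gap that lies well beyond the usual scatter. Compound 2 differs from compound 1 in more than one place, so nothing is drawn from that pair about any single change.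

Compound 3, `COc1ccccc1N1CCN(CCNc2cc(-c3ccccc3)nn(C)c2=O)CC1`, has not yet been measured. It differs from compound 1 in one place: hydrogen in place of isopropylcarbonyl on an aromatic carbon. Going by the values given here, no measured pair shows the effect of removing this group on its own. The expectation is nonetheless a loss of affinity, a step of a 13-fold higher number from compound 1 to compound 3 (1.10 log units; beyond the scatter) in this assay, moving the number upward and beyond the scatter. Compound 3 is accordingly estimated at 8 nM, within a range of 1.5 nM to 40 nM.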

Compound 3, inhibition constant: 2.01 nM
Compound 3: the middle estimate sits 4.0-fold (0.60 log units) above what was measured, within the range that was stated.
By their numbers in this assay, from the lowest: compound 1; then compound 3; then compound 2.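

In this assay, going by these compounds alone, hydrogen in place of isopropylcarbonyl on this aromatic carbon, ortho to a phenyl group, gives a 3.1-fold higher number from compound 1 to compound 3 (0.50 log units; beyond the scatter), the first reading of this change on its own. The group therefore adds to affinity, but its loss does not remove it: compound 3 still gives 2.01 nM, and this stays lower than the number for compound 2, although that pair differs in more than one place. Nothing available accounts for the size of this step.

Going by these compounds, whether the step comes from the carbonyl or from the isopropyl part stays open, and an acetyl, a methyl or an amine on the same carbon would separate these. Also open, on these data alone, is whether the step keeps its size with the longer chain carried by compound 2.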